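A few compounds are considered here, and "the series" means these few. Any claim that something is new, unique, unknown or untested is made for them only; others in the source may bear on it.

Measured so far:
compound 1 `CN(C)C(=O)c1cc2cnc(Nc3ccc(C(=O)NCCCCCN=C=S)cc3F)nc2n1C1CCCC1`: 86.7%
compound 2 `CN(C)C(=O)c1cc2cnc(Nc3ccc(C(=O)NCCCCCCCN=C=S)cc3F)nc2n1C1CCCC1`: 35.8%

In a functional assay on NCI-H1299 cells (Homo sapiens) for inhibition, read by CCK-8 assay, with a stated time of 72 h, tested at 10 uM (a higher number here means a stronger effect of the compound at the concentration tested, a lower number a weaker effect), compound 1 gives 86.7%, the higher of the two numbers. Among the measured compounds shown here, compound 2 gives 35.8%, and the single measured step is a number 50.9 percentage points lower from compound 1 to compound 2 (beyond the scatter). For the measured compounds named here, that step alters the chain end, not the aromatic ring, so no measured step bears directly on the change at hand. Compound 3 `CN(C)C(=O)c1cc2cnc(Nc3ccc(C(=O)NCCCCCN=C=S)cc3O)nc2n1C1CCCC1` differs from compound 1 by hydroxy in place of fluoro on an aromatic carbon. With nothing comparable to lean on, only a modest step in this assay is expected, possibly none beyond the scatter, with wide uncertainty. Compound 3 is therefore estimated at 72% (range 40% to 93%), meaning an expected a number 14.7 percentage points lower from compound 1 to compound 3 (beyond the scatter).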

Compound 3, a percentage reported as inhibition, at one concentration (the size of the read-out at that concentration, not a potency): 80.7%
Compound 3: the middle estimate sits 8.7 percentage points below what was measured; low and high end bracket the measured number.
By their numbers in this assay, from the lowest: compound 2; then compounds 3 and 1 (each within the scatter of the next).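

Hydroxy in place of fluoro on this aromatic carbon gives a number 6 percentage points lower from compound 1 to compound 3 (within the scatter) in this assay. The earlier compounds shown here showed only that the chain end can matter; this step shows that, at the concentration tested, the aromatic position accepts the exchange, with one hydrogen-bond donor and one acceptor entering, without a change beyond the scatter. Nothing available explains this result.

Still open, going by these compounds, is whether an amine or a methoxy group on the same aromatic carbon would read alike. Also open, on these data alone, is whether hydroxy would read the same way on the longer chain of compound 2.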